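Swapping a Nitro Group for Chlorine on a Thiourea

The source may report more compounds than this note shows. Statements on the series, on what has been measured and on what is new or still open speak of the compounds shown alone.

Three compounds share a core and differ only in the ring attached to the thiourea nitrogen. Compound 1 `COc1cc2c(cc1OC)C(=O)C(CC1CCN(C(=S)Nc3ccccc3)CC1)C2` carries a plain phenyl ring there; in a functional assay on the whole organism (strain Swiss albino) with Mus musculus as the target, with a stated time of 0.5 h (a higher number here means that more compound is needed for the effect, a lower number that less compound is needed), compound 1 gives 100 mg/kg. Compound 2 `COc1cc2c(cc1OC)C(=O)C(CC1CCN(C(=S)Nc3cccc([N+](=O)[O-])c3)CC1)C2` carries a 3-nitrophenyl ring instead, but in this assay compound 2 gives "not determined" (no result reported), so no number is known for it and it cannot be placed against compound 1. Compound 3 `COc1cc2c(cc1OC)C(=O)C(CC1CCN(C(=S)Nc3ccc(Cl)cc3)CC1)C2` is the next variation: 4-chlorophenyl in place of 3-nitrophenyl on an amide-type nitrogen. Within the data shown here, with compound 2 lacking a number, the size of the step into compound 3 cannot be read from the data; the only anchor is compound 1, and a change of this kind is not expected to move the result beyond the usual scatter in this assay. Compound 3 is therefore estimated to need about 100 mg/kg in this assay, within a range of 30 mg/kg to 300 mg/kg.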

Compound 3, minimum effective dose: 100 mg/kg
Estimate against measurement, compound 3: no gap at the digits printed; measured number inside the range.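

In this assay, chloro in place of hydrogen on an aromatic carbon gives no change at the digits printed from compound 1 to compound 3 (within the scatter) and so leaves the dose needed for the effect where it was. Among these compounds, this is the first readable comparison at this place on the thiourea, showing that the ring on the amide-type nitrogen can carry this one substituent without a visible shift, while the step between compound 2 and compound 3 cannot be read. Nothing in the data explains this result.

One chloro substituent on one ring says little about the position as a whole, so the result cannot be extended to other groups. From the compounds shown here alone, whether an amine or a carboxylic acid on this phenyl ring, or a longer chain between the ring and the nitrogen, would move the dose remains open.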